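A few compounds are considered here, and "the series" means these few. Any claim that something is new, unique, unknown or untested is made for them only; others in the source may bear on it.

Measured compounds:
- compound 1 `Cc1ccc(NC(=S)Nc2ccc(S(=O)(=O)Nc3ccc(Cl)cc3)cc2)cc1`: in a functional assay on the whole organism with Mus musculus as the target, in the maximal electroshock model, with a stated time of 0.5 h (on this read-out higher numbers stand for an effect only at larger amounts of compound and lower numbers for an effect already at smaller amounts), compound 1 gives 100 mg/kg
- compound 2 `Cc1ccc(NC(=S)Nc2ccc(S(=O)(=O)Nc3ccc(Br)cc3)cc2)cc1`: in this assay compound 2 gives 100 mg/kg

Compound 2 stands level with compound 1 at the digits shown; the single step measured so far, no change at the digits printed from compound 1 to compound 2 (within the scatter), is within the scatter. Nothing here separates the two.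

The next compound, compound 3 `Cc1ccc(NC(=S)Nc2ccc(S(=O)(=O)Nc3ccc(C)cc3)cc2)cc1`, differs from compound 2 in one place: methyl in place of bromo on an aromatic carbon. This change keeps the same heavy-atom count and the same donor and acceptor count, and it sits on the same aromatic carbon that carried chloro and then bromo in the two measured compounds. Going by the values given here, the only step that bears on it is the exchange from compound 1 to compound 2, which showed no change beyond the scatter. With two substituents at that carbon giving the same reading, the expectation for a third small substituent there is no change in this assay beyond the scatter, in either direction.

Compound 3 is therefore estimated at 100 mg/kg, within 50 mg/kg to 300 mg/kg, the expected step being no change at the digits printed from compound 2 to compound 3 (within the scatter).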

Compound 3, minimum effective dose: 300 mg/kg
For compound 3 the middle estimate is 3.0-fold (0.48 log units) below the measured one; low and high end bracket the measured number.
By their numbers in this assay, from the lowest: compounds 1 and 2 (each within the scatter of the next); then compound 3.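

Within the shared core, this aromatic carbon does not tolerate every small substituent equally, although the exchange of chloro for bromo gave no separation. In this assay methyl gives a 3.0-fold higher number from compound 2 to compound 3 (0.48 log units; beyond the scatter) and likewise a 3.0-fold higher number from compound 1 to compound 3 (0.48 log units; beyond the scatter) and thus sets compound 3 apart from both halogen-bearing compounds, with an effect only at a larger amount of compound. The change leaves the heavy-atom count at this place as it was, so that count alone does not track the reading, and no measurement at hand accounts for the gap between methyl and the two halogens.

The compounds shown leave open whether the reading at this carbon follows any ordered trend, since one methyl and two halogens are too few to show one, and a fluoro, an amine, a methoxy group, a carboxylic acid or a longer chain such as ethyl at the same place could fall on either side of the present values. Also open, going by these compounds, is how much the methyl on the other aromatic ring and the thiourea link contribute, as both stay the same across all three compounds.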